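A few compounds are considered here, and "the series" means these few. Any claim that something is new, unique, unknown or untested is made for them only; others in the source may bear on it.

Among the compounds with values here, in an ADME assay on HepG2 cells (Homo sapiens) for inhibition, with a stated time of 72 h (on this read-out higher numbers stand for an effect only at larger amounts of compound and lower numbers for an effect already at smaller amounts), compound 3 `CN(C)CCC(=O)Nc1cccc(-c2nc3ccccc3s2)c1` gives 21000 nM, the only plain number among the three measured compounds. Compound 1 `O=C(Nc1ccc(Cl)cc1)c1cc([N+](=O)[O-])ccc1Cl` gives > 25000 nM, which is a limit rather than a number. Compound 2 `C/C=C/C(=O)Nc1cccc(-c2nc3ccccc3s2)c1` likewise gives > 25000 nM, also a limit. Two of the three values therefore sit at the limit of > 25000 nM in this assay, at which 2 of the 3 values shown sit. Within the data shown here, the one measured step, an at least 1.1-fold lower number from compound 2 to compound 3 (0.07 log units; that floor lies within the scatter), lies within the scatter. Compound 4 `O=C(Nc1cccc(-c2nc3ccccc3s2)c1)c1ccc(Cl)nc1Cl` differs from compound 3 as follows: 2,6-dichloropyridin-3-yl in place of 2-(dimethylamino)ethyl on a carbonyl carbon. Among the measured compounds shown here, no measured step exchanges 2-(dimethylamino)ethyl for 2,6-dichloropyridin-3-yl on a carbonyl carbon, so no change beyond the scatter is expected, and compound 4 is estimated to show a 1.2-fold higher number from compound 3 to compound 4 (0.08 log units; within the scatter). The expected value for compound 4 is 25000 nM, ranging from 9000 nM to 70000 nM.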

Compound 4, half-maximal effective concentration: > 25000 nM
Compound 4 was reported as a limit; the forecaster's own chance of this, stated with the estimate: 60%; the middle value lies on the limit itself.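

Placing 2,6-dichloropyridin-3-yl on the carbonyl carbon in place of 2-(dimethylamino)ethyl gives an at least 1.1-fold higher number from compound 3 to compound 4 (0.07 log units; that floor lies within the scatter), so this aromatic ring shows no change beyond the scatter in this assay. The value of compound 4 is a limit, not a number, and the step from compound 2 to compound 4 cannot be read. This change adds one more compound to a single limit: the limit of > 25000 nM in this assay, at which 3 of the 4 values shown sit.

Going by these compounds, what a longer amine chain or a carboxylic acid on this carbonyl carbon would give stays open. Only a plain number well under that limit could reveal a real step at this place.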